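A few compounds are considered here, and "the series" means these few. Any claim that something is new, unique, unknown or untested is made for them only; others in the source may bear on it.

Measured in an ADME assay on Raji cells (Homo sapiens) for cytotoxicity, with a stated time of 72 h; a higher number here means that more compound is needed for the effect, a lower number that less compound is needed:
- Compound 1 `Cc1cc(NC(=O)Nc2cccc(F)c2)c2ccccc2n1`: > 25000 nM, a limit
- Compound 2 `Cc1cc(NC(=O)Nc2cccc(C(F)(F)F)c2)c2ccccc2n1`: 10000 nM
- Compound 3 `Cc1cc(NC(=O)Nc2cccc(N(C)C)c2)c2ccccc2n1`: > 25000 nM, a limit

Compound 3 has no exact number, only the limit > 25000 nM. Compound 4 `Cc1cc(NC(=O)Nc2cccc(OC(F)(F)F)c2)c2ccccc2n1` carries trifluoromethoxy in place of dimethylamino on an aromatic carbon.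

The nearest measured evidence is an at least 2.5-fold higher number from compound 2 to compound 3 (0.39 log units; beyond the scatter), which, read in reverse, points to a lower number when dimethylamino leaves. an at least 2.5-fold lower number from compound 1 to compound 2 (0.39 log units; beyond the scatter) also shows trifluoromethyl giving a lower number. a step that the two limits leave unreadable from compound 1 to compound 3 adds nothing.

Of the measured groups, the trifluoromethyl of compound 2 at 10000 nM is taken as the closest guide. The expected step is an at least 2.0-fold lower number from compound 3 to compound 4 (0.31 log units; beyond the scatter), a modest one towards a lower number. For compound 4 the estimated value is 12000 nM, with an expected range of 5000 nM to 25000 nM.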

Compound 4, half-maximal effective concentration: 9000 nM
Beside the measured number, compound 4's estimate is 1.3-fold (0.12 log units) above it; the range from low to high includes it.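

At this place, trifluoromethoxy joins trifluoromethyl as a group that gives an exact number in this assay, with an at least 2.7-fold lower number from compound 3 to compound 4 (0.44 log units; beyond the scatter) and an at least 2.7-fold lower number from compound 1 to compound 4 (0.44 log units; beyond the scatter). Exchanging trifluoromethyl for trifluoromethoxy produces no readable change, with a 1.1-fold lower number from compound 2 to compound 4 (0.05 log units; within the scatter). The two larger steps give only a minimum size, because compound 1 and compound 3 each sit at a limit: the limit of > 25000 nM in this assay, at which 2 of the 4 values shown sit.

Still open, on these data alone, is how a primary amine, a carboxylic acid or a longer alkyl chain would read at this place. Also open, as far as these compounds go, is whether any group gives a number clearly lower than those of compound 2 and compound 4.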